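The source may hold more compounds than are shown below. What is called first, only, known or untested is meant among the compounds shown, and "the series" means these compounds.

In a functional assay on HepG2 cells (Homo sapiens) for cytotoxicity, read by MTT assay, with a stated time of 24 h (a lower number here means a stronger inhibitor, a higher number a weaker inhibitor), compound 2 `O=C1/C(=C/c2ccncc2)CN(S(=O)(=O)c2ccc(Br)cc2)C/C1=C\c1ccccc1F` gives 9300 nM and compound 1 `Cc1ccc(S(=O)(=O)N2C/C(=C\c3ccncc3)C(=O)/C(=C/c3ccccc3F)C2)cc1` gives 9700 nM, so the two sit level within the scatter. Compound 3 `CC(=O)Nc1ccc(S(=O)(=O)N2C/C(=C\c3ccncc3)C(=O)/C(=C/c3ccccc3F)C2)cc1` has acetamido in place of bromo on an aromatic carbon, para to a large group: acetamido in place of bromo on an aromatic carbon. Among the measured compounds shown here, the one measured step that bears on this is a 1.0-fold lower number from compound 1 to compound 2 (0.02 log units; within the scatter), for bromo in place of methyl. For the measured compounds named here, no measured step involves acetamido, so on that evidence no change beyond the scatter is expected in this assay, in either direction. The expected step is a 1.1-fold higher number from compound 2 to compound 3 (0.03 log units; within the scatter). The estimate for compound 3 is 10000 nM, with an expected range from 4500 nM to 22000 nM.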

Compound 3, half-maximal inhibitory concentration: 11700 nM
Compound 3: the middle estimate sits 1.2-fold (0.07 log units) below what was measured, and the stated range covers the measured number.
By their numbers in this assay, from the lowest: compounds 2, 1 and 3 (each within the scatter of the next).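

In this assay, the place para to a large group now carries acetamido, with four heavy atoms where bromo has one, plus a hydrogen-bond donor and acceptor, and the readings are a 1.3-fold higher number from compound 2 to compound 3 (0.10 log units; within the scatter) and a 1.2-fold higher number from compound 1 to compound 3 (0.08 log units; within the scatter) for the two comparisons. So methyl, bromo and acetamido all sit level here, and this larger group shifts nothing beyond the scatter. No measured evidence bears on why the three read alike. On these data alone, whether an amine or a carboxylic acid at this place would read differently remains open, as does the effect of a longer chain.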